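Cyclohexenyl Dienones: Estimating a Pyridin-3-yl Analogue

The source may hold more compounds than are shown below. What is called first, only, known or untested is meant among the compounds shown, and "the series" means these compounds.

Compound 1 `CC1=C(/C=C/C(=O)/C=C/c2ccc(Cl)cc2)C(C)(C)CCC1`: 9500 nM
Compound 2 `CC1=C(/C=C/C(=O)/C=C/c2ccccc2Cl)C(C)(C)CCC1`: 11300 nM
Compound 3 `COc1ccccc1/C=C/C(=O)/C=C/C1=C(C)CCCC1(C)C`: 14200 nM

In a functional assay on PC-3 cells (Homo sapiens) for cytotoxicity, read by sulforhodamine B assay, with a stated time of 48 h (a higher number here means a weaker inhibitor, a lower number a stronger inhibitor), compound 2 stands second highest of the three numbers, with compound 1 nearest and compound 3 furthest. Both measured steps, a 1.2-fold higher number from compound 1 to compound 2 (0.08 log units; within the scatter) and a 1.3-fold higher number from compound 2 to compound 3 (0.10 log units; within the scatter), lie within the scatter, so the three aryl variants so far are indistinguishable in this assay.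

Compound 4 `CC1=C(/C=C/C(=O)/C=C/c2cccnc2)C(C)(C)CCC1` differs from compound 2 by pyridin-3-yl in place of 2-chlorophenyl on a double-bonded chain carbon bound to a double-bonded chain carbon. Among the compounds with values here, no measured step exchanges the carbon-only aromatic ring for a ring holding a hetero atom, so there is no direct precedent; the two aryl changes that were measured each gave steps within the scatter. Compound 4 is therefore expected to give 14000 nM in this assay, within 6000 nM to 35000 nM. This estimate means a step of a 1.2-fold higher number from compound 2 to compound 4 (0.09 log units; within the scatter), expected to stay within the scatter.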

Compound 4, half-maximal inhibitory concentration: 10200 nM
For compound 4 the middle estimate is 1.4-fold (0.14 log units) above the measured one; measured number inside the range.
By their numbers in this assay, from the lowest: compounds 1, 4, 2 and 3 (each within the scatter of the next).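

In this assay, replacing a carbon-only aromatic ring with pyridin-3-yl gives a 1.1-fold lower number from compound 2 to compound 4 (0.04 log units; within the scatter) and a 1.1-fold higher number from compound 1 to compound 4 (0.03 log units; within the scatter). Within the data shown here, at this place, on a double-bonded chain carbon bound to a double-bonded chain carbon, a ring with a hetero atom and a hydrogen-bond acceptor is therefore not separated from either chlorophenyl ring, a comparison the earlier compounds could not offer. Nothing available explains this result. The compounds shown leave open whether a ring bearing a carboxylic acid or an amine, or a longer chain in place of the ring, would give a step beyond the scatter here.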